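Methoxy in place of hydroxy across two cores

A few compounds are considered here, and "the series" means these few. Any claim that something is new, unique, unknown or untested is made for them only; others in the source may bear on it.

Compound 1 `O=C(Nc1cccc(-n2cc(-c3ccncc3)c(-c3cc(O)cc(Cl)c3)n2)c1)Nc1ccc(Cl)c(Cl)c1` and compound 2 `COc1cc(Cl)cc(-c2nn(-c3cccc(NC(=O)Nc4ccc(Cl)c(Cl)c4)c3)cc2-c2ccncc2)c1` share one core and differ in a single place: methyl in place of hydrogen on an oxygen on an aromatic ring. In a functional assay on SR cells (Homo sapiens) for inhibition, read by sulforhodamine B assay, with a stated time of 48 h, tested at 10 uM (a lower number here means a stronger effect, a higher number a weaker effect of the compound at the concentration tested), compound 1 gives -21.4%, and compound 2 gives -18.5%, so the change made a number 2.9 percentage points higher from compound 1 to compound 2 (within the scatter). Compound 3 `O=C(Nc1cccc(-n2cc(-c3ccncc3)c(-c3cc(O)cc(Cl)c3)n2)c1)c1cc(C(F)(F)F)cc(C(F)(F)F)c1` carries a different core; the difference between the two cores is not broken down here. In this assay compound 3 gives 3.15%, the highest of the three numbers, and its distance from both compound 1 and compound 2 is beyond the scatter. Compound 4 `COc1cc(Cl)cc(-c2nn(-c3cccc(NC(=O)c4cc(C(F)(F)F)cc(C(F)(F)F)c4)c3)cc2-c2ccncc2)c1`, not yet measured, is derived from compound 3 by the same change: methyl in place of hydrogen on an oxygen on an aromatic ring. The place of the change is the same, word for word, in both pairs.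

The expectation for compound 4 in this assay rests on the step of a number 2.9 percentage points higher from compound 1 to compound 2 (within the scatter), which lay within the scatter. The same change is expected to make a step of similar size, a number 2.9 percentage points higher from compound 3 to compound 4 (within the scatter). Compound 4 is therefore estimated at 6%, with a range from -6% to 18%.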

Compound 4, a percentage reported as activity, at one concentration (the size of the read-out at that concentration, not a potency): 41%
Compound 4: middle estimate off by 35 percentage points, on the low side; measured number outside the range, above it.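

On the core of compound 3, hydroxy to methoxy gives a number 37.9 percentage points higher from compound 3 to compound 4 (beyond the scatter), a weaker effect at the concentration tested in this assay, so the step read on the core of compound 1 did not carry over in size. Among these compounds, the two steps differ: the same change on two cores in this assay, a number 2.9 percentage points higher (within the scatter) from compound 1 to compound 2 and a number 37.9 percentage points higher (beyond the scatter) from compound 3 to compound 4, 35 percentage points apart, beyond the scatter of two such steps This shows that, in this series, the size of this change on one core does not set its size on another, but with only two pairs it gives no rule for which cores respond, and it does not show which part of the difference between the cores is responsible.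

The compounds shown leave open whether the larger step belongs to the methyl on that oxygen specifically or would also appear with an ethoxy, an amine or a fluorine in place of the hydroxy. As far as these compounds go, it also remains open whether the gap between the two steps would hold on further cores, or at other concentrations than the one tested.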